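Working notes: methyl to hydrogen on the phenyl group

The source may hold more compounds than are shown below. What is called first, only, known or untested is meant among the compounds shown, and "the series" means these compounds.

Measured compounds in a functional assay, with a stated time of 90 s; on this read-out lower numbers stand for stronger inhibition and higher numbers for weaker inhibition:
compound 1 `Cc1nc2c3ccccc3ccc2c2nc3c(ccc4ccccc43)c(-c3ccc(O)cc3)c12` — 99 ug/mL
compound 2 `Cc1ccc(-c2c3ccc4ccccc4c3nc3c2c(C)nc2c4ccccc4ccc32)cc1` — 192 ug/mL

Compound 2 is the compound from which the next step starts. Within the data shown here, the only measured step in this assay, a 1.9-fold higher number from compound 1 to compound 2 (0.29 log units; within the scatter), leaves the two numbers within the scatter of one another, so compound 2 does not stand apart from compound 1 in any way the data can support.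

Compound 3 `Cc1nc2c3ccccc3ccc2c2nc3c(ccc4ccccc43)c(-c3ccccc3)c12` differs from compound 2 by hydrogen in place of methyl on an aromatic carbon. Among the measured compounds shown here, no measured step removes a methyl or introduces a hydrogen. For the measured compounds named here, the one step recorded, methyl in place of hydroxy, stayed within the scatter, and that is the only bearing there is. The expectation for compound 3 in this assay is therefore a step of no real size, a 1.1-fold lower number from compound 2 to compound 3 (0.03 log units; within the scatter), in no particular direction. The estimate for compound 3 is 180 ug/mL, with a range from 80 ug/mL to 400 ug/mL.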

Compound 3, half-maximal inhibitory concentration: 188 ug/mL
For compound 3 the middle estimate is 1.0-fold (0.02 log units) below the measured one; the range from low to high includes it.
By their numbers in this assay, from the lowest: compounds 1, 3 and 2 (each within the scatter of the next).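

Working notes: in this assay, hydrogen in place of methyl on the phenyl group, para to a large group, leaves the two compounds within the scatter (a 1.0-fold lower number from compound 2 to compound 3 (0.01 log units; within the scatter)). Among these compounds, the phenyl compound also gives the first direct comparison of hydroxy with hydrogen at this position, and that pair too stays within the scatter (a 1.9-fold higher number from compound 1 to compound 3 (0.28 log units; within the scatter)), so hydroxy, methyl and hydrogen cannot be told apart here on these numbers. No outside evidence bears on this result.

Going by these compounds, whether this position tolerates any substituent or is simply insensitive to small ones remains open, since an amine, a carboxylic acid, a longer alkyl chain or a halogen such as chlorine may or may not separate from hydrogen. Substitution elsewhere on the shared core is likewise untested by these compounds.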